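A few compounds are considered here, and "the series" means these few. Any claim that something is new, unique, unknown or untested is made for them only; others in the source may bear on it.

Measured in an ADME assay on the whole organism (Mus musculus, strain CD1) for metabolic stability, read by LC-MS, with a stated time of 24 h, at a dose of 1 mg/kg by the intravenous route; a higher number here means that the compound lasts longer, a lower number that the compound disappears faster:
compound 1 `CC(C(=O)O)c1nn(Cc2cn3cc(OCC4CC4)c(C(F)(F)F)cc3n2)c2ccccc2c1=O` gives 1.9 h
compound 2 `O=C(O)Cn1nc(Cc2nc3cc(F)c(OCC4CC4)cc3[nH]2)c2ccccc2c1=O` gives 0.4 h
compound 3 `C[C@H](C(=O)O)n1nc(Cn2cc3cc(OCC4CC4)c(Cl)cc3n2)c2ccccc2c1=O` gives 2.4 h

Compound 3 holds the highest number of the three; compound 1 sits within the scatter of it, while compound 2 lies beyond the scatter below it. Compound 4 `O=C(O)Cn1nc(Cn2cc3cc(OCC4CC4)c(Cl)cc3n2)c2ccccc2c1=O` differs from compound 3 in one place: hydrogen in place of methyl on a saturated chain carbon bound to an aromatic nitrogen and a carbonyl carbon. Among the compounds with values here, no pair of measured compounds isolates this change. Compound 2 carries the same carboxymethyl chain on a differently arranged core, and its low number can only be noted. Compound 4 is expected to give up part of the half-life seen for compound 3, with an expected step of a 2.0-fold lower number from compound 3 to compound 4 (0.30 log units; within the scatter) that may not exceed the scatter. The estimate for compound 4 is 1.2 h, within 0.5 h to 2.8 h.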

Compound 4, half-life: 1.4 h
Estimate against measurement, compound 4: 1.2-fold (0.07 log units) below; low and high end bracket the measured number.
By their numbers in this assay, from the lowest: compound 2; then compounds 4, 1 and 3 (each within the scatter of the next).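

In this assay, within the data shown here, the change from 1-carboxyethyl to carboxymethyl gives the only matched reading at this position, with a 1.7-fold lower number from compound 3 to compound 4 (0.23 log units; within the scatter). On this core, the methyl on the saturated chain carbon bound to an aromatic nitrogen and a carbonyl carbon is therefore not shown to matter for half-life. Nothing measured here accounts for the step. Open, on these data alone, is how an ethyl group or two methyl groups on that carbon would read. Also open, as far as these compounds go, is the effect of a primary amide in place of the carboxylic acid.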